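Notes on compound 4 in relation to compound 2

The source may hold more compounds than are shown below. What is called first, only, known or untested is meant among the compounds shown, and "the series" means these compounds.

Three compounds of the series have numbers in a physicochemical assay for lipophilicity, using the shake flask method, in phosphate buffer, measured as octanol-water partition, with a stated time of 30 min, at pH 7.4; a higher number here means a more lipophilic compound, a lower number a more polar compound. Compound 2 `O=C1c2ccccc2CN1c1cnc(NCc2c(F)ccc3c2CCO3)n2cnnc12` gives 2.7 and stands highest of the three. Going by the values given here, compound 1 `Cc1ncccc1-c1cnc(NCc2c(F)ccc3c2CCO3)c2nn(CC#N)c(=O)n12` gives 2.2 in this assay, a number below compound 2 by more than the scatter; no single-point step connects these two, as their cores differ. Among the compounds with values here, compound 3 `CN(C)Cc1ccc2c(c1)CN(c1cnc(NCc3c(F)ccc4c3CCO4)n3cnnc13)C2=O` gives 1.6, and the only measured one-place step is a number 1.10 log units lower from compound 2 to compound 3 (beyond the scatter), a change of (dimethylamino)methyl in place of hydrogen on an aromatic carbon.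

Compound 4 `C[C@H]1CC(=O)N(c2cnc(NCc3c(F)ccc4c3CCO4)n3cnnc23)C1` is not yet measured. It differs from compound 2 by a group of 7 heavy atoms (5 carbon, 1 nitrogen, 1 oxygen; one five-membered non-aromatic ring with 1 hetero atom) in place of a group of 10 heavy atoms (8 carbon, 1 nitrogen, 1 oxygen; one five-membered non-aromatic ring with 1 hetero atom, one six-membered aromatic ring of carbon only), on an aromatic carbon. The step from compound 2 to compound 3 concerns a different position and a different kind of group, so it gives no direct guide; it only shows that single changes at the periphery of this core can move this assay by a large amount. With a smaller group of 7 heavy atoms replacing one of 10 heavy atoms that carried a six-membered aromatic ring of carbon only, a downward step of moderate size is expected for compound 4, namely a number 0.70 log units lower from compound 2 to compound 4 (beyond the scatter). Compound 4 is therefore estimated at 2, within the range 1.4 to 2.6.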

Compound 4, distribution coefficient: 1.8
The estimate for compound 4 lay 0.20 log units above the measured number; the measured number falls inside the stated range.
By their numbers in this assay, from the lowest: compounds 3 and 4 (each within the scatter of the next); then compound 1; then compound 2.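

In this assay the exchange of the whole group on this aromatic carbon gives a number 0.90 log units lower from compound 2 to compound 4 (beyond the scatter) and thus shows that the number responds to the group at this position itself, whereas the earlier step only added (dimethylamino)methyl to a group left in place. Hydrogen-bond donors, hydrogen-bond acceptors and net charge are counted the same in the leaving and entering groups, while the entering group has fewer heavy atoms and lacks the six-membered aromatic ring of carbon only. Compound 3 gives 1.6 and compound 4 gives 1.8 in this assay, values within the scatter of each other, and no measurement at hand explains the step.

The compounds shown leave open how much of the step belongs to the methyl group and how much to the loss of the aromatic ring. A plain 2-oxopyrrolidin-1-yl group, the opposite stereoisomer of the 4-methyl-2-oxopyrrolidin-1-yl group or an amine on that ring would address this.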